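The source may report more compounds than this note shows. Statements on the series, on what has been measured and on what is new or still open speak of the compounds shown alone.

Compound 2 `Nc1nc2cc(-c3nn(CCCCCCCCC(=O)NO)c4ncnc(N)c34)ccc2o1` carries the longest chain in this small set, and in a functional assay on MDA-MB-231 cells (Homo sapiens) for inhibition, read by MTT assay, with a stated time of 72 h (a higher number here means a weaker inhibitor, a lower number a stronger inhibitor), compound 2 gives 30300 nM. That is the higher of the two numbers recorded so far; the only other one belongs to compound 1 `Nc1nc2cc(-c3nn(CC(=O)NO)c4ncnc(N)c34)ccc2o1`, which in this assay gives 6310 nM, a gap that lies beyond the usual scatter. Compound 1 and compound 2 share the same core and the same hydroxamic acid end group, and they differ only in how many saturated chain carbons lie between the aromatic nitrogen and that end group.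

Compound 3 `Nc1nc2cc(-c3nn(CCCCCCC(=O)NO)c4ncnc(N)c34)ccc2o1` sits between them in chain length. Relative to compound 2 the change is hydroxycarbamoyl in place of 2-(hydroxycarbamoyl)ethyl on a saturated chain carbon, six bonds along the chain from an aromatic nitrogen. Among the measured compounds shown here, no measured pair is available that isolates this exact change, so the expectation rests only on the two recorded values, which place the shorter chain of compound 1 at the lower number. On that basis compound 3 is expected to land between the two, and the estimated step of a 2.5-fold lower number from compound 2 to compound 3 (0.40 log units; beyond the scatter) is a moderate fall. For compound 3 the expected value in this assay is 12000 nM, with a range from 5000 nM to 30000 nM.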

Compound 3, half-maximal inhibitory concentration: 8430 nM
For compound 3 the middle estimate is 1.4-fold (0.15 log units) above the measured one; low and high end bracket the measured number.
By their numbers in this assay, from the lowest: compounds 1 and 3 (each within the scatter of the next); then compound 2.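

In this assay, hydroxycarbamoyl in place of 2-(hydroxycarbamoyl)ethyl, on a saturated chain carbon six bonds along the chain from an aromatic nitrogen, gives a 3.6-fold lower number from compound 2 to compound 3 (0.56 log units; beyond the scatter) and so shows that trimming the longest chain in the set moves the number by more than the scatter. The second change, 5-(hydroxycarbamoyl)pentyl in place of hydroxycarbamoyl on a saturated chain carbon bound to an aromatic nitrogen, gives a 1.3-fold higher number from compound 1 to compound 3 (0.13 log units; within the scatter) and so leaves these two chain lengths indistinguishable in this assay. The three compounds therefore do not form a steady climb with chain length: a large difference in length separates compound 1 and compound 3 without a readable change in the number, while the smaller change from compound 3 to compound 2 does give one, and nothing here offers an explanation for this.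

The compounds shown leave open how the number behaves at chain lengths other than these three, and whether a longer chain would carry it further in the same direction. Among the compounds shown here, they also leave open whether the hydroxamic acid end group matters at all, since no compound here replaces it with a carboxylic acid or a primary amide.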